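Working notes on the aryl-nitrogen swap, compound 3 to compound 4

The source may hold more compounds than are shown below. What is called first, only, known or untested is meant among the compounds shown, and "the series" means these compounds.

compound 1 `Cc1ccccc1-c1nn(-c2ccc(C(F)(F)F)cc2)cc1CNCCN1CCN(C)CC1`: 11000 nM
compound 2 `COc1ccc(-n2cc(CNCCN3CCN(C)CC3)c(-c3ccccc3C)n2)cc1`: > 20000 nM
compound 3 `Cc1ccccc1-c1nn(Cc2ccc(F)cc2)cc1CNCCN1CCN(C)CC1`: > 20000 nM

In an ADME assay on Huh-7 cells (Homo sapiens) for cytotoxicity (on this read-out lower numbers stand for higher toxicity in this test and higher numbers for lower toxicity in this test), compound 1 gives 11000 nM. Compound 2 gives only a limit of the assay, > 20000 nM. Compound 3 likewise gives only a limit, > 20000 nM, so compound 3 stands at the limit of > 20000 nM in this assay, at which 2 of the 3 values shown sit, and has no number of its own. Compound 4 `Cc1ccccc1-c1nn(-c2ccccc2Cl)cc1CNCCN1CCN(C)CC1` is not yet measured; it differs from compound 3 by 2-chlorophenyl in place of 4-fluorobenzyl on an aromatic nitrogen. Among the compounds with values here, the steps that bear on it are an at least 1.8-fold higher number from compound 1 to compound 3 (0.25 log units; that floor lies within the scatter) and a step that the two limits leave unreadable from compound 2 to compound 3, neither of which has a readable size, and an at least 1.8-fold higher number from compound 1 to compound 2 (0.25 log units; that floor lies within the scatter) is floored within the scatter as well. In this assay no change beyond the scatter is expected. The estimate for compound 4 is 15000 nM, with a range of 7000 nM to 30000 nM. The expected step is an at least 1.3-fold lower number from compound 3 to compound 4 (0.12 log units; that floor lies within the scatter), within the scatter.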

Compound 4, half-maximal cytotoxic concentration: > 20000 nM
Compound 4: a limit, no number; the forecaster's own chance of this, stated with the estimate: 45%; middle value at least 1.3-fold (0.12 log units) from the limit.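

In this assay compound 4 gives only a limit, not a number, so 2-chlorophenyl on the aromatic nitrogen sits at the same limit as 4-fluorobenzyl and 4-methoxyphenyl: the limit of > 20000 nM in this assay, at which 3 of the 4 values shown sit.
The change from 4-(trifluoromethyl)phenyl gives an at least 1.8-fold higher number from compound 1 to compound 4 (0.25 log units; that floor lies within the scatter) and so shows no separation beyond the scatter.
The steps from compound 2 and from compound 3 to compound 4 join two limits and cannot be read.
On these data alone, how the compounds at the limit rank stays open, as does whether an amine or a carboxylic acid on the phenyl ring would give a readable number.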